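A few compounds are considered here, and "the series" means these few. Any claim that something is new, unique, unknown or untested is made for them only; others in the source may bear on it.

Within the data shown here, in a physicochemical assay for lipophilicity, measured as octanol-water partition (a higher number here means a more lipophilic compound, a lower number a more polar compound), compound 3 `CC(C)=CCn1cc(-c2ccccc2)nn1` gives 2.82, the lowest of the three numbers so far. Compound 1 `CCCc1cn(C/C=C(/C)CCC=C(C)C)nn1` gives 4.05, and compound 2 `CC(C)=CCC/C(C)=C/Cn1cc(-c2ccccc2)nn1` gives 4.91. Compound 4 `CC(C)=CCC/C(C)=C\Cn1cc(-c2ccccc2)nn1` differs from compound 3 in one place: it has 3-methylbut-2-en-1-yl in place of hydrogen on a saturated chain carbon bound to a double-bonded chain carbon. Among the measured compounds shown here, the one measured step that bears on this is the same exchange in the opposite direction, a number 2.09 log units lower from compound 2 to compound 3 (beyond the scatter), which is large and beyond the scatter. Reversing it, a rise of similar size in this assay is expected, an estimated a number 2.08 log units higher from compound 3 to compound 4 (beyond the scatter). The expected value for compound 4 is 4.9, within an estimated range of 4.4 to 5.3.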

Compound 4, partition coefficient: 4.91
Compound 4: the middle estimate sits 0.01 log units below what was measured; low and high end bracket the measured number.
By their numbers in this assay, from the lowest: compound 3; then compound 1; then compounds 2 and 4 (each within the scatter of the next).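

The rise with 3-methylbut-2-en-1-yl in this assay also holds with the double bond drawn Z, not only E: a number 2.09 log units higher from compound 3 to compound 4 (beyond the scatter). Changing that drawn configuration alone moves nothing measurable, with no change at the digits printed from compound 2 to compound 4 (within the scatter) in a pair of this kind: the fact that compounds 2 and 4 differ only in the configuration as drawn. Phenyl in place of propyl on an aromatic carbon goes with a modest step, a number 0.86 log units higher from compound 1 to compound 4 (beyond the scatter).

Still open, from the compounds shown here alone, is how an amine or a longer chain in place of 3-methylbut-2-en-1-yl would read. Also open, going by these compounds, is whether the E and Z forms stay level when propyl replaces phenyl.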